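A Hydroxyacetyl Pyrrolidine Replaces the Acetamidophenyl Arm

This account rests on a few compounds, and the source may have more. Where it says the series, first, only, none or still open, it means among the compounds named here.

Compound 3 `CC(=O)Nc1cccc(-n2c(Nc3ccc(F)cc3)nc3cnc(Nc4ccc(N5CCN(C)CC5)cc4)nc32)c1` sits second highest among the three compounds measured in a functional assay on HCC827 cells (Homo sapiens) for antiproliferative activity, read by MTT assay, with a stated time of 72 h (on this read-out higher numbers stand for weaker inhibition and lower numbers for stronger inhibition), where compound 3 gives 10 nM. Its nearest neighbour is compound 1 `CN1CCN(c2ccc(Nc3ncc4nc(Nc5ccc(F)cc5)n([C@H]5CCCN(S(=O)(=O)C6CC6)C5)c4n3)cc2)CC1`, which in this assay gives 8.6 nM; the gap a 1.2-fold higher number from compound 1 to compound 3 (0.07 log units; within the scatter) lies within the scatter. Compound 2 `CN1CCN(c2ccc(Nc3ncc4nc(Nc5ccc(F)cc5)n([C@H]5CCCNC5)c4n3)cc2)CC1` in this assay gives 38 nM, and the step of a 3.8-fold lower number from compound 2 to compound 3 (0.58 log units; beyond the scatter) is beyond the scatter. Compound 4 `CN1CCN(c2ccc(Nc3ncc4nc(Nc5ccc(F)cc5)n([C@H]5CCN(C(=O)CO)C5)c4n3)cc2)CC1` differs from compound 3 by 1-((hydroxymethyl)carbonyl)pyrrolidin-3-yl in place of 3-acetamidophenyl on an aromatic nitrogen. Within the data shown here, two measured steps bear on this change. Exchanging the aromatic arm for a saturated nitrogen ring whose ring nitrogen carries a cyclopropylsulfonyl, a 1.2-fold higher number from compound 1 to compound 3 (0.07 log units; within the scatter), stayed within the scatter, whereas leaving that ring nitrogen bare, a 4.4-fold higher number from compound 1 to compound 2 (0.65 log units; beyond the scatter), raised the number modestly. In compound 4 the ring nitrogen carries a hydroxymethylcarbonyl rather than a hydrogen, so the change is expected to behave like the former step rather than the latter. For compound 4 a step no larger than the scatter is expected, a 1.2-fold higher number from compound 3 to compound 4 (0.08 log units; within the scatter). Compound 4 is therefore estimated at 12 nM in this assay, within 5 nM to 35 nM.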

Compound 4, half-maximal inhibitory concentration: 380 nM
The estimate for compound 4 lay 32-fold (1.50 log units) below the measured number; measured number outside the range, above it.
By their numbers in this assay, from the lowest: compounds 1 and 3 (each within the scatter of the next); then compound 2; then compound 4.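

In this assay, a saturated nitrogen ring on the aromatic nitrogen did not by itself keep the number low: 1-((hydroxymethyl)carbonyl)pyrrolidin-3-yl gives a 38-fold higher number from compound 3 to compound 4 (1.58 log units; beyond the scatter) and, set against the sulfonylated piperidine, a 44-fold higher number from compound 1 to compound 4 (1.65 log units; beyond the scatter). A group on the ring nitrogen was also no safeguard, since the change from the bare piperidin-3-yl gives a 10-fold higher number from compound 2 to compound 4 (1.00 log units; beyond the scatter), so the hydroxyacetyl pyrrolidine falls behind even the unsubstituted ring. Nothing available explains this loss.

Ring size and the group on the ring nitrogen change together here, so the compounds shown do not separate their contributions. On these data alone, a 1-(cyclopropylsulfonyl)pyrrolidin-3-yl or a 1-((hydroxymethyl)carbonyl)piperidin-3-yl group would pull the two apart, and the opposite stereocentre of the pyrrolidine also remains open.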